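From Diethylamino to Pyrrolidin-1-yl in One Cell Assay

The source may report more compounds than this note shows. Statements on the series, on what has been measured and on what is new or still open speak of the compounds shown alone.

In a functional assay on RPMI-8226 cells (Homo sapiens) for inhibition, read by CCK-8 assay, with a stated time of 72 h (a lower number here means a stronger inhibitor, a higher number a weaker inhibitor), compound 1 `COc1ccc(-c2oc3c(CNCC(=O)O)c(O)ccc3c(=O)c2O)c(OC)c1` gives 66200 nM and compound 2 `CCN(CC)Cc1c(O)ccc2c(=O)c(O)c(-c3cccc(Cl)c3Cl)oc12` gives 60400 nM as its reading, two values within the usual scatter of each other. Compound 3 `O=c1c(O)c(-c2cccc(Cl)c2Cl)oc2c(CN3CCCC3)c(O)ccc12` shares the core of compound 2 but carries pyrrolidin-1-yl in place of diethylamino on a saturated chain carbon bound to an aromatic carbon. Within the data shown here, no measured pair shows what this swap does in this assay so no change beyond the scatter is expected. The expected step (a 1.2-fold lower number from compound 2 to compound 3 (0.08 log units; within the scatter)) stays within that scatter. For compound 3 the estimated value is 50000 nM with an expected range of 20000 nM to 110000 nM in this read-out.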

Compound 3, half-maximal inhibitory concentration: 42800 nM
Compound 3: middle estimate off by 1.2-fold (0.07 log units), on the high side; measured number inside the range.
By their numbers in this assay, from the lowest: compounds 3, 2 and 1 (each within the scatter of the next).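

Among these compounds, this is the first direct reading of this change at this position: in this assay, pyrrolidin-1-yl in place of diethylamino on a saturated chain carbon bound to an aromatic carbon gives a 1.4-fold lower number from compound 2 to compound 3 (0.15 log units; within the scatter) and so no clear change. With the heavy-atom count the same, closing the amine into a five-membered non-aromatic ring does not separate the two compounds here. No supporting evidence is available to explain this result.

On these data alone, whether piperidin-1-yl or morpholin-4-yl at this place would shift the number beyond the scatter remains open. The same holds for a primary amine.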